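Vero cytotoxicity: removing the amide from the shared core

A few compounds are considered here, and "the series" means these few. Any claim that something is new, unique, unknown or untested is made for them only; others in the source may bear on it.

Measured so far in an ADME assay on Vero cells (Chlorocebus sabaeus) for cytotoxicity; on this read-out higher numbers stand for lower toxicity in this test and lower numbers for higher toxicity in this test:
compound 1 `Cn1c(-c2ccc([N+](=O)[O-])cc2)nc2cc(C(F)(F)F)ccc21` gives > 100000 nM, a limit of the assay, not a number.
compound 2 `CCN(CC)CC(=O)Nc1ccc(-c2nc3cc(C(F)(F)F)ccc3n2C)cc1` gives 90000 nM.

Among the measured compounds shown here, compound 2 holds the only numerical reading in this assay; the other reading is the limit (the limit of > 100000 nM in this assay, at which 1 of the 2 values shown sits). For the measured compounds named here, the one measured step, an at least 1.1-fold lower number from compound 1 to compound 2 (0.04 log units; that floor lies within the scatter), stays inside the scatter, so both compounds read as essentially non-toxic here.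

Compound 3 `Cn1c(-c2ccc(N)cc2)nc2cc(C(F)(F)F)ccc21` differs from compound 2 in one place: hydrogen in place of ((diethylamino)methyl)carbonyl on a nitrogen on an aromatic ring. The measured step touches the same aromatic position, but runs from nitro to the amide, not from the amide to hydrogen, so it bears on this change only loosely. With no step beyond scatter anywhere in the series, compound 3 is expected to show a step that stays inside the scatter as well, estimated as a 1.1-fold higher number from compound 2 to compound 3 (0.05 log units; within the scatter). Compound 3 is estimated at 100000 nM, within 30000 nM to 300000 nM, and a reading that is again only a limit would not surprise.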

Compound 3, half-maximal cytotoxic concentration: > 100000 nM
Compound 3: no number, only a limit (the forecaster's own chance of this, stated with the estimate: 50%); the middle value lies on the limit itself.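

Taking ((diethylamino)methyl)carbonyl off the nitrogen on the aromatic ring gives an at least 1.1-fold higher number from compound 2 to compound 3 (0.04 log units; that floor lies within the scatter) in this assay, so the series stays at the top of the read-out with the free amino group as well as with the amide. Among the compounds shown here, compound 3 gives > 100000 nM, which is a limit and not a number, leaving compound 2 as the only compound with a numerical reading: the limit of > 100000 nM in this assay, at which 2 of the 3 values shown sit. The step from nitro to amino cannot be read, as both of its readings are limits.

As far as these compounds go, how far compound 3 lies from compound 2 remains unknown, since the reading gives only a floor for that step. Also open, from the compounds shown here alone, is whether any group on this aromatic carbon, such as a carboxylic acid, a piperazine amide or a longer aminoalkyl chain, would give a number beyond the scatter.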